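This account rests on a few compounds, and the source may have more. Where it says the series, first, only, none or still open, it means among the compounds named here.

Measured compounds in a functional assay on LS174T cells (Homo sapiens) for cytotoxicity, read by MTT assay, with a stated time of 72 h; on this read-out lower numbers stand for stronger inhibition and higher numbers for weaker inhibition:

Compound 1, `COc1ccc(/C=C/C(=O)OCC(=O)Nc2ccccc2)cc1OC`, gives > 200000 nM, which is a limit of the assay and not a number.
Compound 2, `COCOc1cc(/C=C/C(=O)OCC(=O)NCc2ccco2)ccc1OCc1ccccc1`, gives > 200000 nM, again a limit of the assay rather than a number.
Compound 3, `CCOc1ccc(COc2c(OC)cc(/C=C/C(=O)OCC(=O)Nc3ccc(Cl)cc3)cc2OC)cc1`, gives > 200000 nM, also a limit of the assay rather than a number.

Compound 3 therefore stands nowhere in particular on these numbers: its result is a limit, and the two other values shown are limits as well. For the measured compounds named here, what the three share is summed up in the limit of > 200000 nM in this assay, at which 3 of the 3 values shown sit, so nothing in the measured set separates one compound from another, and no step between them can be counted.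

Compound 4, `CCOc1ccc(COc2c(OC)cc(/C=C/C(=O)OCC(=O)Nc3ccccc3)cc2OC)cc1`, has not yet been measured in this assay. It differs from compound 3 in a single place: hydrogen in place of chloro on an aromatic carbon. Going by the values given here, because of the limit of > 200000 nM in this assay, at which 3 of the 3 values shown sit, there is no measured step from which a direction for this change could be read, and the change itself is a small one.

The step from compound 3 to compound 4 is expected to amount to a number no higher from compound 3 to compound 4 (the limit leaves the size open), that is, nothing beyond the usual scatter. Compound 4 is estimated to give 200000 nM in this assay, between 100000 nM and 400000 nM, and most likely it will again be reported only as a limit.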

Compound 4, half-maximal inhibitory concentration: > 200000 nM
Compound 4: no number, only a limit (the forecaster's own chance of this, stated with the estimate: 85%); the middle value lies on the limit itself.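

In this assay compound 4 gives > 200000 nM, which is a limit of the assay and not a number. Compound 3 also gives only a limit, so no step between compound 3 and compound 4 can be read, because all the results share one limit: the limit of > 200000 nM in this assay, at which 4 of the 4 values shown sit.

The compounds shown leave open whether exchanging chloro for hydrogen, or any other structural difference among them, changes cytotoxicity at all.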